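The source may hold more compounds than are shown below. What is called first, only, known or untested is meant among the compounds shown, and "the series" means these compounds.

Measured so far in a functional assay on PC-3 cells (Homo sapiens) for inhibition; a higher number here means a weaker inhibitor of growth, a lower number a stronger inhibitor of growth:
compound 1 `C=C1CCCC(C)(C)C1CC[C@]1(C)CC[C@H]([C@@H](C)C(=O)OC)OO1` gives 3630 nM
compound 2 `C=C1CCC[C@H]2[C@](C)(CC[C@]3(C)CC[C@@H]([C@@H](C)C(=O)O)OO3)[C@@H](C)CC[C@]12C` gives 1770 nM

Compound 2 holds the lower of the two numbers; compound 1 stands higher, and that gap is beyond the scatter. Compound 3 `C=C1CCC[C@H]2[C@](C)(CC[C@]3(C)CC[C@H]([C@@H](C)C(=O)O)OO3)[C@@H](C)CC[C@]12C` is the next compound in the series. Among the compounds with values here, it differs from compound 2 as follows: the two compounds have the same atoms and bonds and differ only in configuration as drawn: 1 of 7 stereo elements differ; a stereocentre at a saturated ring carbon is drawn S in compound 2 and R in compound 3 No measured pair differing only in configuration is available, so the size of this step is uncertain; a modest shift in either direction, or none beyond the scatter, is expected. The expected step is a 1.4-fold higher number from compound 2 to compound 3 (0.15 log units; within the scatter). For compound 3 the estimate in this assay is 2500 nM, in the range 900 nM to 7000 nM.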

Compound 3, concentration for 50% growth inhibition: 1690 nM
The estimate for compound 3 lay 1.5-fold (0.17 log units) above the measured number; the range from low to high includes it.
By their numbers in this assay, from the lowest: compounds 3 and 2 (each within the scatter of the next); then compound 1.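

In this assay, changing the saturated ring carbon stereocentre from S to R gives a 1.0-fold lower number from compound 2 to compound 3 (0.02 log units; within the scatter). Within the data shown here, this is the first pair to isolate configuration, and at this stereocentre the drawn configuration leaves growth inhibition unchanged within the scatter. The comparison reads on this single stereocentre alone: the fact that compounds 2 and 3 differ only in the configuration as drawn

From the compounds shown here alone, whether the same holds when the carboxylic acid is replaced by an amide or a primary alcohol remains open. Going by these compounds, the other stereo elements also remain untested as single changes.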